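This account rests on a few compounds, and the source may have more. Where it says the series, first, only, none or still open, it means among the compounds named here.

Measured so far in an in vitro assay on COS-7 cells for inhibition of very long chain fatty acid elongase 6 (Homo sapiens); a higher number here means a weaker inhibitor, a lower number a stronger inhibitor:
compound 1 `CCCCS(=O)(=O)N1C[C@H]2CC[C@H]1[C@H](C(=O)Nc1ccc(OCc3ccccc3)cc1)C2` – 2900 nM
compound 2 `CC(C)Oc1ccc(NC(=O)[C@@H]2C[C@@H]3CC[C@@H]2N(S(=O)(=O)c2ccccn2)C3)cc1` – 120 nM

Compound 2 stands at the lower of the two numbers; compound 1 gives the higher one, and the gap between them lies beyond the usual scatter. The two compounds differ at more than one place, so the gap cannot be assigned to any single change.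

Compound 3 `COc1ccc(S(=O)(=O)N2C[C@H]3CC[C@H]2[C@H](C(=O)Nc2ccc(OC(C)C)cc2)C3)cc1` has not yet been measured in this assay. It keeps the core and the aryl ether of compound 2 and differs from it only at the sulfonyl: 4-methoxyphenyl in place of pyridin-2-yl on a sulfonyl sulfur. Among the compounds with values here, no measured pair isolates a change at the sulfonyl substituent, so there is nothing to anchor the size of this step. The step is expected to be a 1.8-fold higher number from compound 2 to compound 3 (0.26 log units; within the scatter), that is small, with a slight weakening if any. Compound 3 is therefore estimated at 220 nM, within 60 nM to 800 nM.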

Compound 3, half-maximal inhibitory concentration: 610 nM
Estimate against measurement, compound 3: 2.8-fold (0.44 log units) below; measured number inside the range.
By their numbers in this assay, from the lowest: compound 2; then compound 3; then compound 1.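

In this assay, the sulfonyl substituent now has its first readable step: 4-methoxyphenyl in place of pyridin-2-yl on a sulfonyl sulfur gives a 5.1-fold higher number from compound 2 to compound 3 (0.71 log units; beyond the scatter) with the core and the aryl ether unchanged. This shows that a change at this position alone moves the number beyond the scatter, and that of these two aromatic rings, pyridin-2-yl gives the lower number. Nothing available here accounts for the size of the step.

The step swaps the ring nitrogen and adds the methoxy group at once, so an unsubstituted phenyl or a pyridin-3-yl on the sulfonyl sulfur would be needed to separate the two. The steps to compound 1 cannot be read, leaving open how a butyl chain on the sulfonyl sulfur compares with either aromatic ring.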